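Fluoro for trifluoromethyl on two related cores

This account rests on a few compounds, and the source may have more. Where it says the series, first, only, none or still open, it means among the compounds named here.

Measured so far, in a functional assay on PC-3 cells (Homo sapiens) for cytotoxicity, read by MTT assay, with a stated time of 72 h; a higher number here means a weaker inhibitor, a lower number a stronger inhibitor:
compound 1, `CC1=CCCC(C)(C)C1/C=C/C(=O)/C=C/c1ccccc1C(F)(F)F`, 19000 nM
compound 2, `CC1=CCCC(C)(C)C1/C=C/C(=O)/C=C/c1ccccc1F`, 4800 nM
compound 3, `CC1=C(/C=C/C(=O)/C=C/c2ccccc2C(F)(F)F)C(C)(C)CCC1O`, 3700 nM

Compounds 1 and 2 share one core and differ at a single place: fluoro in place of trifluoromethyl on an aromatic carbon. That change gave a 4.0-fold lower number from compound 1 to compound 2 (0.60 log units; beyond the scatter). Compound 3 carries the trifluoromethyl on a different core; how the two cores differ is not broken down here. Among the three measured compounds compound 3 has the lowest number in this assay, but against compound 2 the gap is within the scatter, so no order between compound 2 and compound 3 is claimed; against compound 1 the gap is beyond the scatter.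

Compound 4, `CC1=C(/C=C/C(=O)/C=C/c2ccccc2F)C(C)(C)CCC1O`, has not been measured in this assay. It stands to compound 3 as compound 2 stands to compound 1: fluoro in place of trifluoromethyl on an aromatic carbon. The two place descriptions read the same word for word, so this is the same change, now on the core of compound 3. The step is expected to be a 2.8-fold lower number from compound 3 to compound 4 (0.45 log units; beyond the scatter), somewhat smaller than the measured one because a 4.0-fold lower number from compound 1 to compound 2 (0.60 log units; beyond the scatter) was seen only once and on a different core, so the step may not carry over in full. For compound 4 the expected value in this assay is 1300 nM, with a range from 500 nM to 4000 nM.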

Compound 4, half-maximal inhibitory concentration: 10400 nM
Compound 4: middle estimate off by 8.0-fold (0.90 log units), on the low side; measured number outside the range, above it.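

Measured in this assay the replacement of trifluoromethyl by fluoro on an aromatic carbon gave a 2.8-fold higher number from compound 3 to compound 4 (0.45 log units; beyond the scatter) and so ran in the opposite direction to the step on the other core. Set side by side, the two steps differ in direction and in a gap larger than their scatter: the same change on two cores in this assay, a 4.0-fold lower number (0.60 log units; beyond the scatter) from compound 1 to compound 2 and a 2.8-fold higher number (0.45 log units; beyond the scatter) from compound 3 to compound 4, 11-fold (1.05 log units) apart, beyond the scatter of two such steps. This shows that, within these two pairs, the effect of the change does not carry from one core to the other, even in sign, so a step read on one core is a poor guide to the other; it does not show what causes the reversal or which core's direction would hold for further compounds, as each core contributes a single pair.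

Open, as far as these compounds go, is whether the reversal belongs to fluoro and trifluoromethyl alone or extends to other groups, such as chloro, methoxy or nitrile, on the same aromatic carbon of both cores. Also open, from the compounds shown here alone, is which feature separating the two cores goes with the reversal, and whether an amine or a carboxylic acid elsewhere on either core would leave the direction of the step intact.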